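A few compounds are considered here, and "the series" means these few. Any claim that something is new, unique, unknown or untested is made for them only; others in the source may bear on it.

In a functional assay on MDA-MB-435 cells (Homo sapiens) for inhibition, read by sulforhodamine B assay, with a stated time of 48 h (a higher number here means a weaker inhibitor of growth, a lower number a stronger inhibitor of growth), compound 1 `Cc1ccc(C2=NN(c3ccc(S(C)(=O)=O)cc3)C(=O)CC2)cc1` gives 120 nM and compound 2 `Cc1cc(O)ccc1C1=NN(c2ccc(S(C)(=O)=O)cc2)C(=O)CC1` gives 1280 nM, the higher of the two numbers, which makes compound 2 the weaker inhibitor. Compound 3 `CCc1ccc(C2=NN(c3ccc(S(C)(=O)=O)cc3)C(=O)CC2)cc1` carries a new group: 4-ethylphenyl in place of 4-hydroxy-2-methylphenyl on a carbon with a double bond to nitrogen, with 4-ethylphenyl in place of 4-hydroxy-2-methylphenyl on a carbon with a double bond to nitrogen. Among the measured compounds shown here, the one measured step that bears on this is an 11-fold higher number from compound 1 to compound 2 (1.03 log units; beyond the scatter), and it is large. Compound 3 lacks the hydroxy group, as compound 1 does, so most of that step is expected to reverse. The estimated step is a 9.1-fold lower number from compound 2 to compound 3 (0.96 log units; beyond the scatter), a large fall. For compound 3 the expected value is 140 nM, within an estimated range of 50 nM to 400 nM.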

Compound 3, concentration for 50% growth inhibition: 220 nM
Estimate against measurement, compound 3: 1.6-fold (0.20 log units) below; the measured number falls inside the stated range.
By their numbers in this assay, from the lowest: compounds 1 and 3 (each within the scatter of the next); then compound 2.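

In this assay, 4-ethylphenyl in place of 4-hydroxy-2-methylphenyl gives a 5.8-fold lower number from compound 2 to compound 3 (0.76 log units; beyond the scatter) and so brings the number back to the level of compound 1. Extending the methyl of compound 1 to the ethyl gives a 1.8-fold higher number from compound 1 to compound 3 (0.26 log units; within the scatter) and that small gap means this position tolerates one extra chain carbon without a change that can be told apart. No measured evidence here explains these results.

The compounds shown do not separate the effect of the hydroxy from that of the added ring methyl in compound 2. As far as these compounds go, how a longer chain such as propyl, or an amine, would behave at this ring position also remains open.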